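The source may hold more compounds than are shown below. What is called first, only, known or untested is meant among the compounds shown, and "the series" means these compounds.

Working notes on the series. Going by the values given here, compound 2 `CCNC(=O)c1noc(-c2cc(C(C)C)c(O)cc2O)c1-c1cc(CNC(C)C)no1` stands highest of the three numbers measured so far: in a functional assay on HCT-116 cells (Homo sapiens) for inhibition (on this read-out lower numbers stand for stronger inhibition and higher numbers for weaker inhibition), compound 2 gives 109 nM. Compound 1 `CCNC(=O)c1noc(-c2cc(C(C)C)c(O)cc2O)c1-c1cc(CO)no1` gives 13 nM, and compound 3 `CCNC(=O)c1noc(-c2cc(C(C)C)c(O)cc2O)c1-c1cc(C(N)=O)no1` gives 79 nM. The step of an 8.4-fold higher number from compound 1 to compound 2 (0.92 log units; beyond the scatter) and the step of a 6.1-fold higher number from compound 1 to compound 3 (0.78 log units; beyond the scatter) both move away from compound 1, while a 1.4-fold lower number from compound 2 to compound 3 (0.14 log units; within the scatter) stays within the scatter.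

Compound 4 `CCNC(=O)c1noc(-c2cc(C(C)C)c(O)cc2O)c1-c1cnn(CC)c1` is not yet measured. The change from compound 2 is 1-ethyl-1H-pyrazol-4-yl in place of 3-((isopropylamino)methyl)-1,2-oxazol-5-yl on an aromatic carbon. Among the compounds with values here, no measured step swaps the whole five-membered ring; the steps only vary the group on it. Among those, the hydroxymethyl of compound 1 gave the lowest number, and the two larger groups of compound 2 and compound 3 sit together. With compound 2 as the start, a modest move to a lower number is expected in this assay, since compound 2 sits at the top of the range; a 2.2-fold lower number from compound 2 to compound 4 (0.34 log units; beyond the scatter) is the expected step, and it may well land within the scatter.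

Compound 4 is therefore estimated at 50 nM, with a range from 15 nM to 200 nM.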

Compound 4, half-maximal inhibitory concentration: 26 nM
Compound 4: the middle estimate sits 1.9-fold (0.28 log units) above what was measured; the measured number falls inside the stated range.
By their numbers in this assay, from the lowest: compounds 1 and 4 (each within the scatter of the next); then compounds 3 and 2 (each within the scatter of the next).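

In this assay, the position can take a change of the whole five-membered aromatic ring, not only of the group on it: 1-ethyl-1H-pyrazol-4-yl gives a 4.2-fold lower number from compound 2 to compound 4 (0.62 log units; beyond the scatter) and a 3.0-fold lower number from compound 3 to compound 4 (0.48 log units; beyond the scatter). Against 3-(hydroxymethyl)-1,2-oxazol-5-yl, the same group gives a 2.0-fold higher number from compound 1 to compound 4 (0.30 log units; within the scatter), so the entering group, with 0 hydrogen-bond donors and no 1,2-oxazole ring, reaches the level set by the hydroxymethyl compound. Nothing at hand gives a reason for these steps.

Open, as far as these compounds go, is how a methyl, a propyl chain or a carboxylic acid in place of the ethyl of 1-ethyl-1H-pyrazol-4-yl would read in this assay. Also open, from the compounds shown here alone, is whether a hydroxymethyl added to that group would change the number at all.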